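Aryl swap on the amine nitrogen: compound 2 to compound 3

A few compounds are considered here, and "the series" means these few. Any claim that something is new, unique, unknown or untested is made for them only; others in the source may bear on it.

Within the data shown here, in a functional assay on HeLa cells (Homo sapiens) for cytotoxicity, read by MTT assay, with a stated time of 48 h (on this read-out lower numbers stand for stronger inhibition and higher numbers for weaker inhibition), compound 2 `COc1cc(N/C(CCNC2=CC(=O)c3ccccc3C2=O)=N\S(=O)(=O)c2ccc(C)cc2)cc(OC)c1OC` gives 3390 nM, the lowest of the two numbers so far; compound 1 `COc1ccc(N/C(CCNC2=CC(=O)c3ccccc3C2=O)=N\S(=O)(=O)c2ccc(C)cc2)cc1` gives 7590 nM, and the step from compound 1 to compound 2 was a 2.2-fold lower number from compound 1 to compound 2 (0.35 log units; beyond the scatter). Compound 3 `Cc1ccc(S(=O)(=O)/N=C(/CCNC2=CC(=O)c3ccccc3C2=O)Nc2cc(F)c(F)c(F)c2)cc1` carries 3,4,5-trifluorophenyl in place of 3,4,5-trimethoxyphenyl on an amine nitrogen. Among the measured compounds shown here, the one measured step that bears on this, from compound 1 to compound 2, also exchanged the aryl on this amine nitrogen and was modest, so at most a modest shift in either direction is expected in this assay, quite possibly none beyond the scatter. Compound 3 is expected at 4500 nM, range 1500 nM to 13000 nM, an expected step of a 1.3-fold higher number from compound 2 to compound 3 (0.12 log units; within the scatter).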

Compound 3, half-maximal inhibitory concentration: 8580 nM
The estimate for compound 3 lay 1.9-fold (0.28 log units) below the measured number; measured number inside the range.
By their numbers in this assay, from the lowest: compound 2; then compounds 1 and 3 (each within the scatter of the next).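

In this assay, 3,4,5-trifluorophenyl does not keep the lower number of 3,4,5-trimethoxyphenyl, with a 2.5-fold higher number from compound 2 to compound 3 (0.40 log units; beyond the scatter) on this amine nitrogen. Against 4-methoxyphenyl, 3,4,5-trifluorophenyl gives a 1.1-fold higher number from compound 1 to compound 3 (0.05 log units; within the scatter) and so no separation, leaving compound 2 alone apart from the other two compounds. No measurement at hand gives a cause for this difference. Going by these compounds, it remains open whether the lower number belongs to the 3,4,5-trimethoxyphenyl group as a whole or could also appear with a 3,4,5-triethoxyphenyl or 3,5-dimethoxyphenyl group, and how an unsubstituted phenyl would compare.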